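Acetyl for 3-chlorophenyl on a piperazine nitrogen

The source may hold more compounds than are shown below. What is called first, only, known or untested is meant among the compounds shown, and "the series" means these compounds.

Measured compounds:
compound 1 `Cc1ccc(-[n+]2noc([O-])c2CN2CCN(c3cccc(Cl)c3)CC2)cc1` — 27.5 ug/mL
compound 2 `[O-]c1on[n+](-c2ccc(Cc3ccc(-[n+]4noc([O-])c4CN4CCNCC4)cc3)cc2)c1CN1CCNCC1` — 14 ug/mL
compound 3 `Cc1ccc(-[n+]2noc([O-])c2CN2CCN(C)C(c3ccccc3)C2)cc1` — 14.4 ug/mL

In an ADME assay on MT4 cells (Homo sapiens) for cytotoxicity, read by MTT assay (a higher number here means that more compound is tolerated, a lower number that less compound is tolerated), compound 1 gives 27.5 ug/mL, the highest of the three numbers. Compound 3 gives 14.4 ug/mL and compound 2 gives 14 ug/mL, but both of these sit within the scatter of compound 1, so the three values cannot be told apart with confidence. Among the compounds with values here, no step between measured compounds that differ in a single place is available, so the three values only show that all of them lie in a narrow band.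

Compound 4 `CC(=O)N1CCN(Cc2c([O-])on[n+]2-c2ccc(C)cc2)CC1` has not been measured. It differs from compound 1 as follows: acetyl in place of 3-chlorophenyl on an amine nitrogen in a ring. Within the data shown here, with no measured step to lean on and the shared core kept intact, the expectation is a change that stays within the scatter in this assay, with no clear direction. The estimated step is therefore a 1.1-fold higher number from compound 1 to compound 4 (0.04 log units; within the scatter). For compound 4 the estimated value is 30 ug/mL, with a range from 12 ug/mL to 75 ug/mL.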

Compound 4, half-maximal cytotoxic concentration: 17.3 ug/mL
Estimate against measurement, compound 4: 1.7-fold (0.24 log units) above, within the range that was stated.
By their numbers in this assay, from the lowest: compounds 2, 3, 4 and 1 (each within the scatter of the next).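

In this assay, within the data shown here, putting acetyl in place of 3-chlorophenyl on an amine nitrogen in a ring gives the first step in this set that changes one place only: a 1.6-fold lower number from compound 1 to compound 4 (0.20 log units; within the scatter). It shows that at this position, a group with no ring, fewer heavy atoms and one hydrogen-bond acceptor can replace a six-membered aromatic ring without a difference that can be told from the scatter. No measurement that bears on this result is available.

On these data alone, whether a benzoyl group or a carboxylic acid on a longer chain at this nitrogen would move the number beyond the scatter remains open. Among these compounds, with only one step at this position, it is also open whether the chlorine or the aromatic ring of the group that leaves matters here at all.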